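This account rests on a few compounds, and the source may have more. Where it says the series, first, only, none or still open, it means among the compounds named here.

Measured so far in a functional assay on DU-145 cells (Homo sapiens) for inhibition; on this read-out lower numbers stand for stronger inhibition and higher numbers for weaker inhibition:

Compound 1 `Oc1ccccc1-c1cc(-c2ccccc2F)cc(-c2ccccc2O)n1`: for compound 1 the read-out stops at a limit, > 50000 nM.
Compound 2 `Oc1ccccc1-c1cc(-c2cccc(F)c2)cc(-c2ccccc2O)n1`: for compound 2 the read-out likewise stops at a limit, > 50000 nM.
Compound 3 `Oc1cccc(-c2cc(-c3ccccc3F)cc(-c3ccccc3O)n2)c1`: compound 3 gives 35600 nM.

Among the compounds with values here, compound 3 thus carries the only actual number; the other two values sit at the limit of > 50000 nM in this assay, at which 2 of the 3 values shown sit. Within the data shown here, the one readable comparison, an at least 1.4-fold lower number from compound 1 to compound 3 (0.14 log units; that floor lies within the scatter), is small and its floor lies within the scatter, so it says little about the size of any change.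

Compound 4 `Oc1cccc(-c2cc(-c3ccc(F)cc3)cc(-c3ccccc3O)n2)c1` differs from compound 3 by 4-fluorophenyl in place of 2-fluorophenyl on an aromatic carbon. The nearest measured parallel, a step that the two limits leave unreadable from compound 1 to compound 2, also shifts the fluorine on the fluorophenyl ring, but with both ends at the limit its size cannot be read. Among the measured compounds shown here, no measured step therefore gives a direction for the change from compound 3 to compound 4, and no step beyond the scatter is expected.

In this assay compound 4 is expected to give about 35000 nM, within 12000 nM to 100000 nM. The estimated step of a 1.0-fold lower number from compound 3 to compound 4 (0.01 log units; within the scatter) is expected to stay within the scatter.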

Compound 4, half-maximal inhibitory concentration: > 50000 nM
Compound 4 ended at the assay's limit; the forecaster's own chance of this, stated with the estimate: 35%; middle value at least 1.4-fold (0.15 log units) away from the limit.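

Placing 4-fluorophenyl instead of 2-fluorophenyl on the aromatic carbon opposite the ring nitrogen, with the 3-hydroxyphenyl group kept, gives the first readable fluorine shift in this assay: an at least 1.4-fold higher number from compound 3 to compound 4 (0.14 log units; that floor lies within the scatter). The floor of that step lies within the scatter, so this position has not yet shown a change beyond the scatter, and the true size of the step has no upper bound. Compound 3 remains the only compound with an actual number, and the rest of the series rests on one assay limit: the limit of > 50000 nM in this assay, at which 3 of the 4 values shown sit.

Still open, from the compounds shown here alone, is whether an amine or a carboxylic acid on the ring at this position, in place of fluorine, would give a number clearly under that limit. Also open, going by these compounds, is the real distance between compound 3 and compound 4, which a limit cannot tell.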